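The compounds below may be only part of what the source reports. "The series", "measured", "known", "first", "only" and "open" are said of these compounds alone.

Values so far in a functional assay on T29Kt1 cells (Homo sapiens) for cytotoxicity, read by sulforhodamine B assay, with a stated time of 3 days; on this read-out lower numbers stand for stronger inhibition and higher numbers for weaker inhibition
- compound 1 (`O=Cc1cn(Cc2ccc(Cl)cc2Cl)c2ccccc12`) gives 1580 nM
- compound 2 (`OCc1cn(Cc2ccccc2Cl)c2ccccc12`) gives 2510 nM
- compound 3 (`OCc1cn(Cc2ccc(Cl)cc2)c2ccccc12`) gives 79 nM

Compound 3 holds the lowest of these three numbers, and its gaps to compound 1 and compound 2 both lie beyond the scatter. The next compound is compound 4 (`OCc1cn(Cc2ccc(Cl)cc2Cl)c2ccccc12`), which has chloro in place of hydrogen on an aromatic carbon of compound 3, ortho to a large group and meta to a chloro group (chloro in place of hydrogen on an aromatic carbon).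

Going by the values given here, no pair of measured compounds isolates this change, so its size in this assay cannot be read directly. Two values guide the expectation. Compound 2, which has a chloro group ortho to a large group, gives a higher number (2510 nM) than compound 3. Compound 4 also shares both chloro groups with compound 1 (1580 nM).

A rise in the number, meaning weaker inhibition, is expected beyond the scatter, with an estimated 3.8-fold higher number from compound 3 to compound 4 (0.58 log units; beyond the scatter) as the step. The estimated value for compound 4 is 300 nM within an expected range of 70 nM to 1500 nM for the coming measurement.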

Compound 4, half-maximal inhibitory concentration: 1580 nM
Beside the measured number, compound 4's estimate is 5.3-fold (0.72 log units) below it; the measured number lies above the stated range.
By their numbers in this assay, from the lowest: compound 3; then compounds 1, 4 and 2 (each within the scatter of the next).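

In this assay, chloro in place of hydrogen on an aromatic carbon, ortho to a large group and meta to a chloro group, carries a large cost on compound 3 (a 20-fold higher number from compound 3 to compound 4 (1.30 log units; beyond the scatter)). The same kind of change made on compound 2 stays small (a 1.6-fold lower number from compound 2 to compound 4 (0.20 log units; within the scatter)), so the outcome of adding a chloro group depends on the compound that receives it, and the dichloro pattern gives no gain over the single ortho chloro. With both chloro groups in place, hydroxymethyl in place of formyl makes no visible difference (no change at the digits printed from compound 1 to compound 4 (within the scatter)).

Nothing measured here bears on the reason for these steps. Open, as far as these compounds go, are whether formyl in place of hydroxymethyl would matter on compound 3, and how a carboxylic acid or an amine at that carbon, or fluoro or methyl in place of the ortho chloro, would read.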